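Shortening the Linker Chain Toward the Fluorophenyl Amide

This account rests on a few compounds, and the source may have more. Where it says the series, first, only, none or still open, it means among the compounds named here.

Compound 2 `O=C(CCCCc1cn(Cc2ccc3oc(-c4ccccc4)cc(=O)c3c2)nn1)Nc1ccc(F)cc1` was tested in an assay on isolated protein for inhibition of Amine oxidase [flavin-containing] B (Homo sapiens), read by fluorescence and spectrophotometry (on this read-out lower numbers stand for stronger inhibition and higher numbers for weaker inhibition), where compound 2 gives 15600 nM. Its closest measured relative is compound 1 `O=C(CCCCc1cn(Cc2ccc3oc(-c4ccccc4)cc(=O)c3c2)nn1)Nc1ccccc1`; in this assay compound 1 gives 15600 nM, and the step of no change at the digits printed from compound 1 to compound 2 (within the scatter) shows that a fluoro in place of hydrogen on an aromatic carbon left the read-out unchanged. Compound 3 `O=C(CCc1cn(Cc2ccc3oc(-c4ccccc4)cc(=O)c3c2)nn1)Nc1ccc(F)cc1` keeps the shared core and the fluorophenyl amide but differs by (4-fluorophenyl)carbamoyl in place of 2-((4-fluorophenyl)carbamoyl)ethyl on a saturated chain carbon, two bonds along the chain from an aromatic carbon, so the amide now sits on a shorter chain. Going by the values given here, no measured step between these compounds changes the chain length, and the one measured step addressed only the fluoro and lay within the scatter. There is therefore no measured basis for expecting a step of any direction, only uncertainty about the size. Compound 3 is estimated at 15000 nM, within a range of 4000 nM to 60000 nM, which means an expected step of a 1.0-fold lower number from compound 2 to compound 3 (0.02 log units; within the scatter).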

Compound 3, half-maximal inhibitory concentration: 15600 nM
For compound 3 the middle estimate is 1.0-fold (0.02 log units) below the measured one, within the range that was stated.
By their numbers in this assay, from the lowest: compounds 1, 2 and 3 (each within the scatter of the next).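

In this assay, (4-fluorophenyl)carbamoyl in place of 2-((4-fluorophenyl)carbamoyl)ethyl gives no change at the digits printed from compound 2 to compound 3 (within the scatter), so changing the length of the chain, like the earlier fluoro swap, leaves the number where it was. The comparison with the amide lacking fluorine reads the same way: (4-fluorophenyl)carbamoyl in place of 2-(phenylcarbamoyl)ethyl gives no change at the digits printed from compound 1 to compound 3 (within the scatter). Nothing available here accounts for this level result.

The compounds shown leave open whether any change at this position can move the number at all, since the chain length and the fluoro have so far made no difference. A carboxylic acid or an amine in place of the amide, or a much longer chain, could still give a different reading.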